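Chloro in place of hydrogen on compound 3

The source may report more compounds than this note shows. Statements on the series, on what has been measured and on what is new or still open speak of the compounds shown alone.

- compound 1 `O=[N+]([O-])c1ccc2c(ccn2-c2ccc(O[C@H]3O[C@H](CO)[C@@H](O)[C@H](O)[C@@H]3O)c(Cl)c2)c1` at 99%
- compound 2 `OC[C@H]1O[C@H](Oc2ccc(-n3ccc4ccccc43)cc2F)[C@@H](O)[C@@H](O)[C@@H]1O` at 98%
- compound 3 `OC[C@H]1O[C@H](Oc2ccc(N3CCc4ccccc43)cc2)[C@@H](O)[C@@H](O)[C@@H]1O` at 97%

These values all come from one read-out. In an ADME assay on a cell-free system (plasma, Homo sapiens) for protein binding, read by LC-MS, with a stated time of 5 h, tested at 10 uM, compound 3 stands within the scatter of compound 2, and its unbound fraction exceeds that of compound 1 by more than the scatter.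

Compound 4 `OC[C@H]1O[C@H](Oc2ccc(N3CCc4ccccc43)cc2Cl)[C@@H](O)[C@@H](O)[C@@H]1O` is compound 3 with chloro in place of hydrogen on an aromatic carbon. Among the compounds with values here, no measured pair isolates this change. Compound 1 also carries chloro and gives 99% but differs from compound 3 elsewhere too.

The step expected in this assay is small, toward more binding, and the estimated a 1.5-fold lower unbound fraction from compound 3 to compound 4 (0.18 log units; within the scatter) stays within the scatter. For compound 4 the expected value is 98% (range 96.5% to 99.3%).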

Compound 4, plasma protein binding in the plasma assay: 99%
Estimate against measurement, compound 4: 2.0-fold (0.30 log units) (unbound fraction) above, within the range that was stated.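

With chloro in place of hydrogen on this aromatic carbon, ortho to a large group, the change is now isolated in the plasma assay (a 3.0-fold lower unbound fraction from compound 3 to compound 4 (0.48 log units; beyond the scatter)), going from compound 3 (97%) to compound 4 (99%), with more of compound 4 bound to plasma protein. In a physicochemical assay for solubility, using the shake flask method, measured as thermodynamic solubility, with a stated time of 2 h, at pH 6.5 (on this read-out lower numbers stand for lower solubility and higher numbers for higher solubility), compound 3 (31 ug/mL) and compound 4 (21 ug/mL) show that the same change stays within the scatter (a 1.5-fold lower number from compound 3 to compound 4 (0.17 log units; within the scatter)). No available evidence bears on the reason for either result.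

Open, from the compounds shown here alone, is how a carboxylic acid or an amine would behave on this carbon. Also open, going by these compounds, is whether this chloro step carries over to other cores.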